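The compounds below may be only part of what the source reports. "The series", "measured", "known", "first", "only" and "open" are said of these compounds alone.

Compound 1 `FC(F)(F)Oc1ccc(-c2ccc(-c3ccc(-c4nc5ccccc5[nH]4)cc3)cc2)cc1`: 38000 nM
Compound 2 `Oc1ccc(-c2ccc(-c3ccc(-c4nc5ccccc5[nH]4)cc3)cc2)cc1`: 33100 nM
Compound 3 `Cc1ccc2[nH]c(-c3ccc(-c4ccc(-c5ccc(OC(F)(F)F)cc5)cc4)cc3)nc2c1`: 3560 nM

These three compounds were measured in a functional assay on A549 cells (Homo sapiens) for inhibition, read by sulforhodamine B assay; a higher number here means a weaker inhibitor of growth, a lower number a stronger inhibitor of growth. Compound 4 `Cc1ccc2[nH]c(-c3ccc(-c4ccc(-c5ccc(O)cc5)cc4)cc3)nc2c1` has not been measured yet. Compound 4 differs from compound 3 by hydrogen in place of trifluoromethyl on an oxygen on an aromatic ring. The same change, (hydrogen in place of trifluoromethyl on an oxygen on an aromatic ring), is made from compound 1 to compound 2, where it gave a 1.1-fold lower number from compound 1 to compound 2 (0.06 log units; within the scatter). The cores of the two pairs differ by methyl in place of hydrogen on an aromatic carbon, a change that gave an 11-fold lower number from compound 1 to compound 3 (1.03 log units; beyond the scatter). As the first change hardly moved the number, a similarly small step is expected from compound 3 to compound 4, namely a 1.1-fold lower number from compound 3 to compound 4 (0.03 log units; within the scatter). This expectation rests on a single example, a 1.1-fold lower number from compound 1 to compound 2 (0.06 log units; within the scatter), so it carries wide uncertainty. For compound 4 the estimate is 3300 nM, expected to fall between 1400 nM and 8000 nM.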

Compound 4, concentration for 50% growth inhibition: 3520 nM
Compound 4: middle estimate off by 1.1-fold (0.03 log units), on the low side, within the range that was stated.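

Replacing trifluoromethyl with hydrogen on the oxygen again left the number in this assay essentially unmoved on the methyl-bearing core, with a 1.0-fold lower number from compound 3 to compound 4 (0.00 log units; within the scatter), so this change carried across the two cores: the same change on two cores in this assay, a 1.1-fold lower number (0.06 log units; within the scatter) from compound 1 to compound 2 and a 1.0-fold lower number (0.00 log units; within the scatter) from compound 3 to compound 4, 1.1-fold (0.06 log units) apart, within the scatter of two such steps. The methyl change also carried across, with a 9.4-fold lower number from compound 2 to compound 4 (0.97 log units; beyond the scatter), and its size held with either group on the oxygen: the same change on two cores in this assay, an 11-fold lower number (1.03 log units; beyond the scatter) from compound 1 to compound 3 and a 9.4-fold lower number (0.97 log units; beyond the scatter) from compound 2 to compound 4, 1.1-fold (0.06 log units) apart, within the scatter of two such steps. In these four compounds the two changes therefore behave as if independent, but this is a single square of compounds and shows neither why that is nor that it extends to other groups or cores.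

Going by these compounds, it remains open whether the same holds with an amine or a carboxylic acid in place of the hydroxy group. On these data alone, a longer chain in place of the methyl group is equally open.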